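Ester swap in a series sitting at the assay ceiling

The source may report more compounds than this note shows. Statements on the series, on what has been measured and on what is new or still open speak of the compounds shown alone.

Measured compounds:
compound 1 `C=C1[C@H](OC(C)=O)[C@@H](OC(C)=O)[C@@H](OC(C)=O)C(C)(C)/C=C/[C@H](C)[C@H](OC(=O)c2ccccc2)[C@@]2(O)C[C@@](C)(OC(=O)C(C)(C)C)[C@H](OC(C)=O)[C@@H]2[C@H]1OCC(C)C`: in a functional assay on MCF7 cells (Homo sapiens) for antiproliferative activity, read by MTT assay, with a stated time of 48 h (on this read-out higher numbers stand for weaker inhibition and lower numbers for stronger inhibition), compound 1 gives > 100000 nM, which is a limit of the assay.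
compound 2 `C=C1[C@H](OC(C)=O)[C@@H](OC(C)=O)[C@@H](OC(C)=O)C(C)(C)/C=C/[C@H](C)[C@H](OC(=O)c2ccccc2)[C@@]2(O)C[C@@](C)(OC(=O)c3cccc(C)c3)[C@H](OC(C)=O)[C@@H]2[C@H]1OCC(C)C`: in this assay compound 2 gives > 100000 nM, again a limit.
compound 3 `C=C1[C@H](OC(C)=O)[C@@H](OC(=O)c2cccc(C)c2)[C@@H](OC(C)=O)C(C)(C)/C=C/[C@H](C)[C@H]2O[C@]3(C)C[C@@]2(OC(=O)c2ccccc2)[C@H]([C@H]3OC(C)=O)[C@H]1OCC(C)C`: in this assay compound 3 gives > 100000 nM, also a limit.

Compound 2 and compound 1 share one core and differ by tert-butyl in place of 3-methylphenyl on a carbonyl carbon. The step that the two limits leave unreadable from compound 2 to compound 1 cannot be sized, as both values sit at the limit of > 100000 nM in this assay, at which 3 of the 3 values shown sit. Compound 3 carries a different core from compound 2; the difference between the two cores is not broken down here.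

Compound 4 `C=C1[C@H](OC(C)=O)[C@@H](OC(=O)C(C)(C)C)[C@@H](OC(C)=O)C(C)(C)/C=C/[C@H](C)[C@H]2O[C@]3(C)C[C@@]2(OC(=O)c2ccccc2)[C@H]([C@H]3OC(C)=O)[C@H]1OCC(C)C` is not yet measured. It differs from compound 3 by tert-butyl in place of 3-methylphenyl on a carbonyl carbon, the same change as from compound 2 to compound 1, at the same kind of place. Compound 4 is expected to stay at the assay limit, the expected step that the limit leaves unreadable from compound 3 to compound 4 resting on the unreadable step that the two limits leave unreadable from compound 2 to compound 1 and on compound 3 sitting at the limit of > 100000 nM in this assay, at which 3 of the 3 values shown sit. The estimated value for compound 4 is 150000 nM, with a range from 50000 nM to 500000 nM.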

Compound 4, half-maximal inhibitory concentration: > 100000 nM
Compound 4: no number, only a limit; the forecaster's own chance of this, stated with the estimate: 85%; the middle value does not contradict the limit.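

In this assay compound 4 gives > 100000 nM as a limit of the assay. Compound 3 also sits at a limit, so no size can be read for the change from 3-methylphenyl to tert-butyl between compound 3 and compound 4. The compounds shown leave open how either ester or either core bears on antiproliferative activity, as none yields a number: the limit of > 100000 nM in this assay, at which 4 of the 4 values shown sit.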